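The source may report more compounds than this note shows. Statements on the series, on what has been measured and on what is new or still open speak of the compounds shown alone.

Values in a functional assay on A549 cells (Homo sapiens) for cytotoxicity, read by MTT assay, with a stated time of 72 h; a higher number here means a weaker inhibitor, a lower number a stronger inhibitor:
compound 1 `COc1ncc(-c2ccc3nc(NC(=O)NCC(=O)N4CCCCC4)nn3c2)cc1NS(=O)(=O)c1ccc(F)cc1`: 2060 nM
compound 2 `COc1ncc(-c2ccc3nc(NC(=O)N(C)C)nn3c2)cc1NS(=O)(=O)c1ccc(F)cc1`: 1190 nM
compound 3 `COc1ncc(-c2ccc3nc(NC(=O)NC4CC4)nn3c2)cc1NS(=O)(=O)c1ccc(F)cc1`: 210 nM

Compound 3 stands lowest of the three numbers shown, and its gap to each of the other two is beyond the scatter. Compound 4 `COc1ncc(-c2ccc3nc(NC(=O)NCCN4CCCCC4)nn3c2)cc1NS(=O)(=O)c1ccc(F)cc1` is not yet measured in this assay. The change from compound 3 is 2-(piperidin-1-yl)ethyl in place of cyclopropyl on an amide-type nitrogen.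

For the measured compounds named here, two measured steps bear on this. Going by the values given here, the one that exchanges the group on the same amide-type nitrogen is a 9.8-fold lower number from compound 1 to compound 3 (0.99 log units; beyond the scatter); there the larger group with a piperidine ring gave the higher number and cyclopropyl the lower. The second, a 5.7-fold lower number from compound 2 to compound 3 (0.75 log units; beyond the scatter), also shows cyclopropyl on this position with the lower number. Compound 4 reverses the direction of the first of these, replacing cyclopropyl by a larger group that again carries a piperidine ring. A step up in number, of modest size and beyond the scatter, is therefore expected. Compound 4 is expected to give 900 nM, in a range from 300 nM to 2700 nM, which means an expected step of a 4.3-fold higher number from compound 3 to compound 4 (0.63 log units; beyond the scatter).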

Compound 4, half-maximal inhibitory concentration: 610 nM
Beside the measured number, compound 4's estimate is 1.5-fold (0.17 log units) above it; measured number inside the range.
By their numbers in this assay, from the lowest: compound 3; then compounds 4, 2 and 1 (each within the scatter of the next, the first and the last beyond it).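

In this assay, a chain ending in a piperidine ring on the amide-type nitrogen does not match cyclopropyl (a 2.9-fold higher number from compound 3 to compound 4 (0.46 log units; beyond the scatter)), so compound 3 keeps the lowest number of the four. The link to the ring counts as well as the ring itself: (piperidin-1-yl)methyl in place of (piperidin-1-yl)carbonyl on the saturated chain carbon is a step beyond the scatter (a 3.4-fold lower number from compound 1 to compound 4 (0.53 log units; beyond the scatter)). Against the far smaller dimethylamino, (2-(piperidin-1-yl)ethyl)amino cannot be told apart (a 2.0-fold lower number from compound 2 to compound 4 (0.29 log units; within the scatter)), so heavy-atom count alone does not order these compounds.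

Open, from the compounds shown here alone, is whether a cyclobutyl group on this nitrogen, or a morpholine ring or a longer chain in place of 2-(piperidin-1-yl)ethyl, would change the number. No measurement shown gives a reason for any of these steps.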